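Methoxy to hydroxy on the pendant ring

The compounds below may be only part of what the source reports. "The series", "measured", "known", "first", "only" and "open" are said of these compounds alone.

Among the measured compounds shown here, compound 2 `COc1ccc(C(CC/N=C(\N)NCCCc2c[nH]cn2)c2ccccn2)cc1` stands lowest of the two numbers so far in a functional assay on cardiac atrium for agonist activity at histamine H2 receptor (Cavia porcellus) (a lower number here means a less potent compound, a higher number a more potent compound, by a factor of ten per unit of this negative logarithm), where compound 2 gives 7.44. For the measured compounds named here, its nearest neighbour is compound 1 `Cc1ccc(C(CC/N=C(\N)NCCCc2c[nH]cn2)c2ccccn2)cc1`, which in this assay gives 7.71; the one measured step, a number 0.27 log units lower from compound 1 to compound 2 (within the scatter), describes that pair and is within the scatter. Compound 3 `N/C(=N\CCC(c1ccc(O)cc1)c1ccccn1)NCCCc1c[nH]cn1` is the next member: hydrogen in place of methyl on an oxygen on an aromatic ring. The step from compound 1 to compound 2 is the only one that touches the same place on the ring, and it changed the number by a number 0.27 log units lower from compound 1 to compound 2 (within the scatter), so the series gives no evidence that substitution at this position moves this assay beyond the scatter. Going by the values given here, no measured pair covers a free hydroxy, so the direction of this particular change is not supported by data; the working expectation is a step of about a number 0.14 log units lower from compound 2 to compound 3 (within the scatter) from compound 2 to compound 3, that is, no movement beyond the scatter, with a slightly wider band to allow for the untested group. Compound 3 is therefore estimated at 7.3, expected to fall between 6.7 and 7.9.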

Compound 3, negative logarithm of the half-maximal effective concentration: 6.63
Beside the measured number, compound 3's estimate is 0.67 log units above it; measured number below the stated range.
By their numbers in this assay, from the lowest: compound 3; then compounds 2 and 1 (each within the scatter of the next).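

In this assay, the group on this aromatic carbon now shows an effect that the first pair did not: methyl and methoxy stay within the scatter of each other, whereas hydrogen in place of methyl on the oxygen gives a number 0.81 log units lower from compound 2 to compound 3 (beyond the scatter) and sets the free hydroxy apart. Measured against the methyl compound, the free hydroxy gives a number 1.08 log units lower from compound 1 to compound 3 (beyond the scatter), the larger of the two new steps, so compound 3 lies beyond the scatter from both neighbours and is the least potent of the three. The loss therefore follows the change from methoxy to hydroxy rather than substitution at this place in general, but nothing available here accounts for the difference between the two groups.

Going by these compounds, it remains open whether an amine or a carboxylic acid on this aromatic carbon would fall with compound 3 or stay level with compound 1 and compound 2. On these data alone, it is equally open whether a longer ether such as ethoxy would hold the number of compound 2, and whether the step from methoxy to hydroxy keeps its size on a different core.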